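A Chloro Group on the Phenyl Ring of Compound 2

A few compounds are considered here, and "the series" means these few. Any claim that something is new, unique, unknown or untested is made for them only; others in the source may bear on it.

Of the compounds shown here, two sharing one core have so far been measured in a functional assay on HepG2 cells (Homo sapiens) for inhibition, read by MTT assay, with a stated time of 48 h (on this read-out lower numbers stand for stronger inhibition and higher numbers for weaker inhibition), as a pair. Compound 1 `COc1ccc(-c2nc3c(c(-c4ccccc4)nn3-c3ccccc3)c(-c3ccc(N4CCCCC4)cc3)c2C#N)cc1` gives 12500 nM and compound 2 `N#Cc1c(-c2ccccc2)nc2c(c(-c3ccccc3)nn2-c2ccccc2)c1-c1ccc(N2CCCCC2)cc1` gives 30900 nM as the higher of the two numbers, which means the weaker inhibition. Compound 3 `N#Cc1c(-c2ccc(Cl)cc2)nc2c(c(-c3ccccc3)nn2-c2ccccc2)c1-c1ccc(N2CCCCC2)cc1` carries chloro in place of hydrogen on an aromatic carbon of compound 2 (counted as chloro in place of hydrogen on an aromatic carbon), so that phenyl becomes 4-chlorophenyl. Going by the values given here, that carbon is the one bearing methoxy in compound 1. Among the compounds with values here, the only measured step bearing on this change is hydrogen in place of methoxy at that carbon, which gives a 2.5-fold higher number from compound 1 to compound 2 (0.39 log units; beyond the scatter) and is modest but beyond the scatter. It runs from a substituted ring to an unsubstituted one, and chloro is not methoxy, so it offers thin support. In this assay a similarly modest move toward a lower number is therefore expected, estimated as a 2.1-fold lower number from compound 2 to compound 3 (0.31 log units; beyond the scatter) for this change. Compound 3 is estimated at 15000 nM with 6000 nM to 35000 nM as the expected range.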

Compound 3, half-maximal inhibitory concentration: 3210 nM
Estimate against measurement, compound 3: 4.7-fold (0.67 log units) above, outside the stated range (below it).
By their numbers in this assay, from the lowest: compound 3; then compound 1; then compound 2.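

Going by these compounds alone, at this aromatic carbon, in this assay, chloro in place of hydrogen gives a much larger change (a 9.6-fold lower number from compound 2 to compound 3 (0.98 log units; beyond the scatter)) than the only earlier step there, hydrogen in place of methoxy (a 2.5-fold higher number from compound 1 to compound 2 (0.39 log units; beyond the scatter)). Chloro in place of methoxy also gives a lower number (a 3.9-fold lower number from compound 1 to compound 3 (0.59 log units; beyond the scatter)), so the two substituted compounds are separated from each other as well as from compound 2, and the identity of the group at this carbon matters, not merely its presence. With both of its steps beyond the scatter, compound 3 now holds the lowest number of the three, and the order at this position runs from chloro through methoxy to hydrogen, although nothing shown here explains that order.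

The compounds shown leave open whether bromo, fluoro, an amine or a carboxylic acid at this same carbon would extend or break that order, since chloro and methoxy are the only groups shown there. They also leave open whether chloro would give a similar change on the other phenyl rings of the shared core, where every compound shown still carries the same groups.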